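Swapping an oxolanyl for a methyl on an aromatic nitrogen

The compounds below may be only part of what the source reports. "The series", "measured", "known", "first", "only" and "open" are said of these compounds alone.

Measured so far:
- compound 1, `C[C@@H]1CCCN1c1c(C#N)c2c(N)nc(Nc3ccn(C)n3)cc2n1C`: 234 nM
- compound 2, `Cc1c(Nc2nc(N)c3c(C#N)c(N4CCC[C@H]4C)n(C)c3n2)cnn1[C@@H]1CCOC1`: 20 nM
- compound 3, `C[C@H]1CCCN1c1c(C#N)c2c(N)ncnc2n1C`: 5660 nM

In an assay on isolated protein for inhibition of Leucine-rich repeat serine/threonine-protein kinase 2 (Homo sapiens), read by TR-FRET and LanthaScreen, with stated times of 50 min and 30 min, in the presence of a further agent that is not named here (on this read-out higher numbers stand for weaker inhibition and lower numbers for stronger inhibition), compound 2 gives the lowest number of the three; compound 1 and compound 3 both sit far enough away that the gaps are beyond the scatter, so compound 2 is the most potent of the measured set.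

Compound 4, `Cc1c(Nc2nc(N)c3c(C#N)c(N4CCC[C@H]4C)n(C)c3n2)cnn1C`, differs from compound 2 by methyl in place of oxolan-3-yl on an aromatic nitrogen. The oxolan-3-yl is replaced by a single carbon on the same aromatic nitrogen.

Within the data shown here, no measured pair shows this exact change. Compound 1, which also carries a methyl on its ring nitrogen, gives a higher number than compound 2, so a modest loss is expected here: the step of a 3.0-fold higher number from compound 2 to compound 4 (0.48 log units; beyond the scatter) is expected to be small to moderate, toward weaker inhibition. Compound 4 is therefore estimated at 60 nM, within a range of 20 nM to 200 nM.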

Compound 4, half-maximal inhibitory concentration: 75 nM
Beside the measured number, compound 4's estimate is 1.3-fold (0.10 log units) below it; measured number inside the range.
By their numbers in this assay, from the lowest: compound 2; then compound 4; then compound 1; then compound 3.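

Among these compounds, compound 2 and compound 4 differ in one place only, so this pair gives the first direct reading at this aromatic nitrogen: a 3.8-fold higher number from compound 2 to compound 4 (0.57 log units; beyond the scatter) when methyl replaces oxolan-3-yl. The position responds to the group it carries, but the modest size of the step shows that inhibition on this core does not depend on the oxolane ring, its oxygen or its stereocentre. Nothing measured here explains why the larger group gives the lower number.

From the compounds shown here alone, whether the ring oxygen or simply the size of the group matters remains open, and a cyclopentyl or an ethyl on the same nitrogen would help separate the two. The mirror-image oxolan-3-yl also remains untested among the compounds shown.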